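Swapping the pyridine amide for a semicarbazide

The compounds below may be only part of what the source reports. "The series", "measured", "known", "first", "only" and "open" are said of these compounds alone.

Measured so far:
- compound 1 `C[C@@]1(c2ccc(Cl)cc2Cl)OC[C@@H](COc2ccc(N3CCN(c4ccc(NC(=O)c5cccnc5)cc4)CC3)cc2)O1`: 0.998 h
- compound 2 `C[C@]1(c2ccc(Cl)cc2Cl)OC[C@@H](COc2ccc(N3CCN(c4ccc(NC(=O)c5cccnc5)cc4)CC3)cc2)O1`: 0.148 h

In an ADME assay on microsomes from liver (Homo sapiens) for metabolic stability, read by HPLC, tested at 1 uM (on this read-out higher numbers stand for a longer-lived compound and lower numbers for a shorter-lived compound), compound 1 gives 0.998 h, the higher of the two numbers. Compound 2 gives 0.148 h, and the step of a 6.7-fold lower number from compound 1 to compound 2 (0.83 log units; beyond the scatter) rests on the fact that compounds 1 and 2 differ only in the configuration as drawn alone, since these two share every atom and bond.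

Compound 3 `C[C@@]1(c2ccc(Cl)cc2Cl)OC[C@@H](COc2ccc(N3CCN(c4ccc(NC(=O)NN)cc4)CC3)cc2)O1` is not yet measured. It differs from compound 1 by aminoamino in place of pyridin-3-yl on a carbonyl carbon, so the pyridin-3-yl carbonyl amide becomes an aminocarbamoyl amide. For the measured compounds named here, the only measured step, from compound 1 to compound 2, leaves this part of the molecule untouched and so says nothing about how the change to compound 3 will read. The expectation for compound 3 therefore rests on compound 1 alone, with a wide range: the step of a 1.1-fold lower number from compound 1 to compound 3 (0.04 log units; within the scatter) is estimated as no clear shift beyond the scatter, and compound 3 is expected to give 0.9 h, between 0.3 h and 3 h.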

Compound 3, half-life in the Homo sapiens assay: 0.335 h
Compound 3: the middle estimate sits 2.7-fold (0.43 log units) above what was measured; low and high end bracket the measured number.
By their numbers in the Homo sapiens assay, from the lowest: compound 2; then compound 3; then compound 1.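

In the Homo sapiens assay the pyridin-3-yl on the carbonyl carbon turns out not to be a silent part of the molecule: aminoamino in its place gives a 3.0-fold lower number from compound 1 to compound 3 (0.47 log units; beyond the scatter) and so shortens the half-life. For the compounds shown here, until now the only step was one of configuration, and this is the first step that comes from changing the atoms themselves, here at the far end of the molecule from that stereocentre. In a physicochemical assay for solubility, read by HPLC, in phosphate buffer, measured as kinetic solubility, at pH 7.4 (a higher number here means a more soluble compound, a lower number a less soluble compound), compound 1 gives 4.2 nM and compound 3 gives 9.3 nM as the same swap moves the number the other way, so the shorter half-life comes with a measured gain in solubility: the measured solubility of compound 1, 4.2 nM, and of compound 3, 9.3 nM, a 2.2-fold higher number (0.35 log units; beyond the scatter)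

Whether the ring that leaves or the nitrogens that enter account for these steps stays open, since one swap changes both at once. A phenyl ring on the same carbonyl carbon would separate the two, and how the swap reads in the configuration of compound 2 is also unknown.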